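The source may hold more compounds than are shown below. What is called first, only, known or untested is meant among the compounds shown, and "the series" means these compounds.

Measured compounds:
compound 1, `O=C1C(=O)N(CCCn2cc(COc3cc(=O)oc4ccccc34)nn2)c2ccc(I)cc21`, 65% in a functional assay on HCT-116 cells (Homo sapiens) for inhibition, read by sulforhodamine B assay, with a stated time of 48 h, tested at 50 uM; on this read-out higher numbers stand for more inhibition of growth at the one concentration tested and lower numbers for less inhibition of growth;
compound 2, `COc1ccc2c(c1)C(=O)C(=O)N2CCCCn1cc(COc2cc(=O)oc3ccccc23)nn1`, 48%;
compound 3, `O=C1C(=O)N(CCCCn2cc(COc3cc(=O)oc4ccccc34)nn2)c2ccc(Br)cc21`, 59%.

Compound 1 gives the highest of the three numbers, but compound 3 lies within the scatter of it, and only compound 2 sits clearly below, beyond the scatter. Compound 4, `O=C1C(=O)N(CCCn2cc(COc3cc(=O)oc4ccccc34)nn2)c2ccc([N+](=O)[O-])cc21`, has not yet been measured. It differs from compound 1 by nitro in place of iodo on an aromatic carbon. The only step shown is a number 11 percentage points higher from compound 2 to compound 3 (beyond the scatter), which concerns an exchange of a different group and so gives only weak guidance; no step shows a nitro group. A small change is therefore expected, in either direction or none beyond the scatter. Compound 4 is estimated at 55%, within a range from 35% to 75%. The expected step is a number 10 percentage points lower from compound 1 to compound 4 (within the scatter).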

Compound 4, percent growth inhibition at one concentration: 60%
Compound 4: the middle estimate sits 5 percentage points below what was measured, within the range that was stated.
By their numbers in this assay, from the lowest: compound 2; then compounds 3, 4 and 1 (each within the scatter of the next).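

On the aromatic carbon that holds the iodo group in compound 1, a nitro group gives a number 5 percentage points lower from compound 1 to compound 4 (within the scatter) in this assay. This position therefore accepts a swap from a single iodine atom to a nitro group of three heavy atoms with two hydrogen-bond acceptors, with no change beyond the scatter. No measurement at hand explains this result. From the compounds shown here alone, what an amine or a carboxylic acid would do on this same carbon stays open. Also open, going by these compounds, is whether nitro gives a similar number with a longer chain.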